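Swapping the arylidene group on a shared core toward a methoxyphenyl

The source may hold more compounds than are shown below. What is called first, only, known or untested is meant among the compounds shown, and "the series" means these compounds.

Of the compounds shown here, three of one core have been measured. In a functional assay on NCI-H460 cells (Homo sapiens) for inhibition, read by MTT assay, with a stated time of 72 h (on this read-out higher numbers stand for weaker inhibition and lower numbers for stronger inhibition), compound 3 `CN(C)CCn1c(=O)c(=Cc2ccc(F)cc2F)s/c1=C1\C(=O)Nc2cc(F)ccc21` gives 3200 nM, while compound 1 `CCN(CC)CCCn1c(=O)c(=Cc2cc(OC)c(OC)c(OC)c2)s/c1=C1\C(=O)Nc2ccc(C)cc21` gives 2670 nM and compound 2 `CN(C)CCn1c(=O)c(=Cc2ccc(F)c(F)c2)s/c1=C1\C(=O)Nc2cc(F)ccc21` gives 6400 nM; compound 3 sits within the scatter of both, so the three numbers cannot be ordered. Within the data shown here, the one single-point step, a 2.0-fold lower number from compound 2 to compound 3 (0.30 log units; within the scatter), also stays within the scatter. Compound 4 `COc1ccc(C=c2s/c(=C3\C(=O)Nc4cc(F)ccc43)n(CCN(C)C)c2=O)cc1` differs from compound 3 by 4-methoxyphenyl in place of 2,4-difluorophenyl on a double-bonded chain carbon bound to an aromatic carbon. Among the measured compounds shown here, no measured step exchanges fluorines for a methoxy group, and compound 1 carries its methoxy groups on a differently substituted core, so it bears only loosely. Compound 4 is therefore expected near compound 3, with a 1.1-fold lower number from compound 3 to compound 4 (0.03 log units; within the scatter) inside the scatter, estimated at 3000 nM (range 1000 nM to 10000 nM).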

Compound 4, half-maximal inhibitory concentration: 2200 nM
The estimate for compound 4 lay 1.4-fold (0.13 log units) above the measured number, and the stated range covers the measured number.
By their numbers in this assay, from the lowest: compounds 4, 1, 3 and 2 (each within the scatter of the next, the first and the last beyond it).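

In this assay, among these compounds, the 4-methoxyphenyl group gives the first step beyond the scatter at this place, on a double-bonded chain carbon bound to an aromatic carbon, when it replaces 3,4-difluorophenyl (a 2.9-fold lower number from compound 2 to compound 4 (0.46 log units; beyond the scatter)). Replacing 2,4-difluorophenyl instead stays within the scatter (a 1.5-fold lower number from compound 3 to compound 4 (0.16 log units; within the scatter)), so the change separates compound 4 from only one of the two difluorophenyl compounds. Nothing at hand accounts for this step. The compounds shown leave open how an unsubstituted phenyl or a 4-aminophenyl group would read at this place. They also leave open whether 4-methoxyphenyl would read the same on the core of compound 1.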